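Butoxy to methyl: from compound 2 to compound 3

This account rests on a few compounds, and the source may have more. Where it says the series, first, only, none or still open, it means among the compounds named here.

Compound 1 `O=C(NNc1ccccc1F)c1ccccc1NS(=O)(=O)c1cnc(O)nc1O` gives > 20000 nM in a functional assay on SGC-7901 cells (Homo sapiens) for antiproliferative activity, read by MTT assay, with a stated time of 24 h (a higher number here means a weaker inhibitor, a lower number a stronger inhibitor), and that reading is a limit of the assay, not a number. Among the measured compounds shown here, compound 2 `CCCCOc1ccc(C(=O)NNC(=O)c2ccccc2NS(=O)(=O)c2cnc(O)nc2O)cc1` gives 6890 nM in this assay and holds the only actual number so far. Compound 3 `Cc1ccc(C(=O)NNC(=O)c2ccccc2NS(=O)(=O)c2cnc(O)nc2O)cc1` has methyl in place of butoxy on an aromatic carbon, para to a large group (methyl in place of butoxy on an aromatic carbon). For the measured compounds named here, no measured step covers this change. A modest move towards weaker inhibition in this assay is expected, with the estimated size given as (a 1.3-fold higher number from compound 2 to compound 3 (0.12 log units; within the scatter)). Compound 3 is estimated at 9000 nM (expected range 3500 nM to 20000 nM).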

Compound 3, half-maximal inhibitory concentration: 15500 nM
Compound 3: middle estimate off by 1.7-fold (0.24 log units), on the low side; low and high end bracket the measured number.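

Among the compounds shown here, replacing butoxy with methyl on the aromatic carbon para to a large group gives the first measured step at this position in this assay: a 2.2-fold higher number from compound 2 to compound 3 (0.35 log units; beyond the scatter), which puts the butoxy compound on the stronger side. The comparison at the other end yields only a floor, an at least 1.2-fold lower number from compound 1 to compound 3 (0.11 log units; that floor lies within the scatter), and sets no order between those two compounds. The value of compound 1 is a limit of the assay, not a number: the limit of > 20000 nM in this assay, at which 1 of the 3 values shown sits.

On these data alone, whether chain length or the oxygen of butoxy carries the step remains open. A butyl group, a longer alkoxy chain or an amine at this position would separate the two.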